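Replacing 4-butoxyphenyl with 2-fluorophenyl: notes on compound 3

A few compounds are considered here, and "the series" means these few. Any claim that something is new, unique, unknown or untested is made for them only; others in the source may bear on it.

In a functional assay on A549 cells (Homo sapiens) for antiproliferative activity, read by MTT assay, with a stated time of 24 h (on this read-out higher numbers stand for weaker inhibition and lower numbers for stronger inhibition), two compounds have been read so far. Compound 1 (`Cc1ccccc1NNC(=O)c1ccccc1NS(=O)(=O)c1cnc(O)nc1O`) reads > 20000 nM as a limit of the assay, not a number. Going by the values given here, compound 2 (`CCCCOc1ccc(C(=O)NNC(=O)c2ccccc2NS(=O)(=O)c2cnc(O)nc2O)cc1`) gives 4960 nM as the only actual number, so it has no numerical neighbour. Compound 3 (`O=C(NNC(=O)c1ccccc1NS(=O)(=O)c1cnc(O)nc1O)c1ccccc1F`) carries 2-fluorophenyl in place of 4-butoxyphenyl on a carbonyl carbon. Among the compounds with values here, no measured step isolates this change, yet weaker inhibition beyond the usual scatter is expected. The expected change is a 3.0-fold higher number from compound 2 to compound 3 (0.48 log units; beyond the scatter) as a rough estimate. For compound 3 the estimate is 15000 nM with an expected range from 6000 nM to 40000 nM in this assay.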

Compound 3, half-maximal inhibitory concentration: 7150 nM
Compound 3: the middle estimate sits 2.1-fold (0.32 log units) above what was measured; the measured number falls inside the stated range.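

On a carbonyl carbon, 2-fluorophenyl in place of 4-butoxyphenyl gives a 1.4-fold higher number from compound 2 to compound 3 (0.16 log units; within the scatter) in this assay, so the butoxy chain is not needed for a measurable value here. (2-Fluorophenyl)carbonyl in place of 2-methylphenyl on an amine nitrogen gives an at least 2.7-fold lower number from compound 1 to compound 3 (0.44 log units; beyond the scatter). Compound 1 stands at a limit of the assay, not a number: the limit of > 20000 nM in this assay, at which 1 of the 3 values shown sits.

As far as these compounds go, whether a plain phenyl, 4-methoxyphenyl or an alkyl chain on that carbonyl carbon would read alike remains open. The compounds shown also do not separate the contribution of the carbonyl from that of the ring substituent.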